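Estimating a methylcarbamoyl analogue in a thiazole ether series

The source may report more compounds than this note shows. Statements on the series, on what has been measured and on what is new or still open speak of the compounds shown alone.

Of the compounds shown here, three sharing one core have been measured in a functional assay on HEK293 cells for antagonist activity at proteinase-activated receptor 4 (Homo sapiens), read by FLIPR and calcium flux, with a stated time of 30 min; on this read-out higher numbers stand for weaker inhibition and lower numbers for stronger inhibition. Compound 1 `COc1cc(OCc2csc(-c3ccc(C(C)(C)O)cc3)n2)c2cc(-c3cn4nc(OC)sc4n3)oc2c1` gives 2.4 nM, compound 2 `COc1cc(OCc2csc(-c3ccc(OC)nc3)n2)c2cc(-c3cn4nc(OC)sc4n3)oc2c1` gives 0.8 nM, and compound 3 `COc1cc(OCc2csc(-c3cccc(C(=O)N(C)C)c3)n2)c2cc(-c3cn4nc(OC)sc4n3)oc2c1` gives 0.8 nM. Compound 3 stands level with compound 2 at the digits shown, and the two together hold the lowest numbers; the step of a 3.0-fold lower number from compound 1 to compound 3 (0.48 log units; beyond the scatter) is the only change beyond the scatter, while no change at the digits printed from compound 2 to compound 3 (within the scatter) shows none. Compound 4 `CNC(=O)c1ccc(-c2nc(COc3cc(OC)cc4oc(-c5cn6nc(OC)sc6n5)cc34)cs2)cc1` carries 4-(methylcarbamoyl)phenyl in place of 3-(dimethylcarbamoyl)phenyl on an aromatic carbon. The measured steps show that exchanging the aryl group on this ring has so far moved this assay only modestly, so a modest change, if any, is expected for a 1.9-fold higher number from compound 3 to compound 4 (0.27 log units; within the scatter). Compound 4 is therefore estimated at 1.5 nM, within a range of 0.5 nM to 4.5 nM.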

Compound 4, half-maximal inhibitory concentration: 0.4 nM
The estimate for compound 4 lay 3.8-fold (0.57 log units) above the measured number; the whole stated range lies above it.
By their numbers in this assay, from the lowest: compounds 4, 2 and 3 (each within the scatter of the next); then compound 1.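

In this assay, 4-(methylcarbamoyl)phenyl fits this position as well as the groups already seen, with a 2.0-fold lower number from compound 3 to compound 4 (0.30 log units; within the scatter) and a 2.0-fold lower number from compound 2 to compound 4 (0.30 log units; within the scatter). Methylcarbamoyl in place of 1-hydroxy-1-methylethyl on the same phenyl gives a 6.0-fold lower number from compound 1 to compound 4 (0.78 log units; beyond the scatter), so a phenyl ring with a group at its 4-position can reach the low numbers of compound 2 and compound 3. Nothing available explains these steps.

Compound 4 changes both the place of the amide and its methyl count relative to compound 3, and these two changes cannot be separated here. From the compounds shown here alone, what a 4-(dimethylcarbamoyl)phenyl group or a carboxylic acid would do at this position remains open.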